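The source may report more compounds than this note shows. Statements on the series, on what has been measured and on what is new or still open speak of the compounds shown alone.

Compound 1 `CC(O)(CSc1cccc(S(F)(F)(F)(F)F)c1)C(=O)Nc1ccc(C#N)c(C(F)(F)F)c1` and compound 2 `CC(O)(CSc1cccc(S(F)(F)(F)(F)F)c1)C(=O)Nc1ccc([N+](=O)[O-])c(C(F)(F)F)c1` are built on the same core. In a functional assay on CWR22R cells (Homo sapiens) for antiproliferative activity, read by propidium iodide staining, with a stated time of 96 h (on this read-out lower numbers stand for stronger inhibition and higher numbers for weaker inhibition), compound 1 gives 20400 nM, while compound 2 gives 8800 nM. Among the compounds with values here, the one change between them is nitro in place of cyano on an aromatic carbon, and it brought a 2.3-fold lower number from compound 1 to compound 2 (0.37 log units; beyond the scatter). Compound 3 `CC(O)(CSc1ccc(S(F)(F)(F)(F)F)cc1)C(=O)Nc1ccc(C#N)cc1C(F)(F)F` has the same atoms as compound 1 joined differently; the difference between the two cores is not broken down here. In this assay compound 3 gives 13200 nM, a number within the scatter of both compound 2 and compound 1. Compound 4 `CC(O)(CSc1ccc(S(F)(F)(F)(F)F)cc1)C(=O)Nc1ccc([N+](=O)[O-])cc1C(F)(F)F` differs from compound 3 by the same kind of change, (nitro in place of cyano on an aromatic carbon), where the place is meta to a trifluoromethyl group rather than ortho to it. Resting on a 2.3-fold lower number from compound 1 to compound 2 (0.37 log units; beyond the scatter), compound 4 is expected to show a 2.2-fold lower number from compound 3 to compound 4 (0.34 log units; beyond the scatter). Compound 4 is therefore estimated at 6000 nM, expected between 3000 nM and 12000 nM.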

Compound 4, half-maximal inhibitory concentration: 13100 nM
For compound 4 the middle estimate is 2.2-fold (0.34 log units) below the measured one, outside the stated range (above it).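

On the core of compound 3, nitro in place of cyano gave a 1.0-fold lower number from compound 3 to compound 4 (0.00 log units; within the scatter) in this assay, so the two compounds read alike. Set beside the step on the core of compound 1, this result differs from it by no more than repeated measurements of two such steps would allow: the same change on two cores in this assay, a 2.3-fold lower number (0.37 log units; beyond the scatter) from compound 1 to compound 2 and a 1.0-fold lower number (0.00 log units; within the scatter) from compound 3 to compound 4, 2.3-fold (0.36 log units) apart, within the scatter of two such steps. Within the data shown here, the data therefore do not show that the change behaves differently on the two cores, yet they do not establish that its effect carries over either, since each core offers only one step.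

The compounds shown carry only cyano or nitro at this place on the ring. As far as these compounds go, how an amine or a carboxylic acid there would read remains open.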